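Fluorophenyl pyridazinone amides: cytotoxicity on A549 cells

The source may hold more compounds than are shown below. What is called first, only, known or untested is meant among the compounds shown, and "the series" means these compounds.

Measured so far:
compound 1, `Cc1cc(=O)n(-c2ccc(F)cc2)nc1C(=O)Nc1ccc(Oc2ncnc3[nH]ccc23)cc1`: > 60000 nM
compound 2, `Cc1cc(=O)n(-c2cccc(F)c2)nc1C(=O)Nc1ccc(Oc2ncnc3[nH]ccc23)cc1`: 34800 nM
compound 3, `Cc1cc(=O)n(-c2ccc(F)cc2)nc1C(=O)Nc1ccc(Oc2ncnc3[nH]ccc23)c(F)c1`: 42400 nM

All three were run in a functional assay on A549 cells (Homo sapiens) for cytotoxicity, read by MTT assay, with a stated time of 72 h; a higher number here means a weaker inhibitor, a lower number a stronger inhibitor. For compound 1 the result is a limit of the assay and not a number; it sits at the limit of > 60000 nM in this assay, at which 1 of the 3 values shown sits. Compound 2 gives 34800 nM in this assay, and compound 3 gives 42400 nM. The change from compound 1 to compound 2 is 3-fluorophenyl in place of 4-fluorophenyl on an aromatic nitrogen; it gave an at least 1.7-fold lower number from compound 1 to compound 2 (0.23 log units; that floor lies within the scatter). The cores of compound 1 and compound 3 differ by fluoro in place of hydrogen on an aromatic carbon, which gave an at least 1.4-fold lower number from compound 1 to compound 3 (0.15 log units; that floor lies within the scatter). The values of compound 2 and compound 3 lie within the scatter of each other, and no order between them is claimed.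

Compound 4, `Cc1cc(=O)n(-c2cccc(F)c2)nc1C(=O)Nc1ccc(Oc2ncnc3[nH]ccc23)c(F)c1`, has not yet been measured. It differs from compound 3 by 3-fluorophenyl in place of 4-fluorophenyl on an aromatic nitrogen, the same change that separates compound 1 from compound 2, at a place described in identical words. In this assay compound 4 is expected to show a 1.7-fold lower number from compound 3 to compound 4 (0.23 log units; within the scatter), resting on the step of an at least 1.7-fold lower number from compound 1 to compound 2 (0.23 log units; that floor lies within the scatter) and on the value of compound 3, 42400 nM. That earlier step starts from a limit and so gives only a floor for its size; the estimate for compound 4 therefore stays close to compound 3 with room on the lower side. Compound 4 is estimated at 25000 nM, between 10000 nM and 60000 nM.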

Compound 4, half-maximal inhibitory concentration: 31500 nM
Beside the measured number, compound 4's estimate is 1.3-fold (0.10 log units) below it, within the range that was stated.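

Carried onto the core of compound 3, 3-fluorophenyl in place of 4-fluorophenyl gives a 1.3-fold lower number from compound 3 to compound 4 (0.13 log units; within the scatter) in this assay; set beside the earlier step, the comparison reads: the same change on two cores in this assay, an at least 1.7-fold lower number (0.23 log units; that floor lies within the scatter) from compound 1 to compound 2 and a 1.3-fold lower number (0.13 log units; within the scatter) from compound 3 to compound 4; the limit leaves it open whether they differ

Carried onto the core of compound 2, fluoro in place of hydrogen on an aromatic carbon gives a 1.1-fold lower number from compound 2 to compound 4 (0.04 log units; within the scatter) in this assay; set beside the earlier step, the comparison reads: the same change on two cores in this assay, an at least 1.4-fold lower number (0.15 log units; that floor lies within the scatter) from compound 1 to compound 3 and a 1.1-fold lower number (0.04 log units; within the scatter) from compound 2 to compound 4; the limit leaves it open whether they differ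

Both new steps stay within the scatter, so the pairs with measured numbers show no clear effect of either change, and they do not show that either change carries from one core to another with a fixed size, as both earlier steps start from a limit.

The compounds shown differ only in where fluoro sits, so it remains open whether an amine or a carboxylic acid on the phenyl group would give a step beyond the scatter in this assay. On these data alone, the true size of any step starting from compound 1 also remains open, and with it whether the two changes add up on this series.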